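Aryl swap on the five-membered ring: compound 3 against compound 2

The compounds below may be only part of what the source reports. "The series", "measured", "known", "first", "only" and "open" are said of these compounds alone.

Measured so far in an assay on HEK293 cells for displacement of a labelled ligand from Melanocortin receptor 4 (Homo sapiens); a higher number here means a weaker inhibitor, a lower number a stronger inhibitor:
compound 1 `CC(C)[C@H](NC(=O)CCN(C)C)c1cccc(F)c1N1CCN(C(=O)[C@@H]2CN(C(C)C)C[C@H]2c2ccc(F)c(Cl)c2)CC1` — 260 nM
compound 2 `CC(C)[C@H](NC(=O)CCN(C)C)c1cccc(F)c1N1CCN(C(=O)[C@@H]2CN(C(C)C)C[C@H]2c2cc(F)ccc2F)CC1` — 2050 nM

Compound 2 stands with the highest of the two numbers in this assay; its nearest neighbour is compound 1, and the step of a 7.9-fold higher number from compound 1 to compound 2 (0.90 log units; beyond the scatter) separates the two. Compound 3 `CC(C)[C@H](NC(=O)CCN(C)C)c1cccc(F)c1N1CCN(C(=O)[C@@H]2CN(C(C)C)C[C@H]2c2ccc(C(F)(F)F)c(F)c2)CC1` differs from compound 2 in one place only: 3-fluoro-4-(trifluoromethyl)phenyl in place of 2,5-difluorophenyl on a saturated ring carbon. Among the compounds with values here, the one measured step that bears on this change is a 7.9-fold higher number from compound 1 to compound 2 (0.90 log units; beyond the scatter), where the aryl group on the same saturated ring carbon was exchanged. Compound 3 carries substitution at the same positions of the aryl ring as compound 1, so a step back toward lower numbers in this assay is expected, though of uncertain size. For compound 3 the expected step is a 3.7-fold lower number from compound 2 to compound 3 (0.57 log units; beyond the scatter). The estimate for compound 3 in this assay is 550 nM, with a range from 150 nM to 1800 nM.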

Compound 3, inhibition constant: 51 nM
Beside the measured number, compound 3's estimate is 11-fold (1.03 log units) above it, outside the stated range (below it).
By their numbers in this assay, from the lowest: compound 3; then compound 1; then compound 2.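

In this assay the aryl group on this saturated ring carbon moves the number in both directions: the loss seen with 2,5-difluorophenyl is more than recovered in a 40-fold lower number from compound 2 to compound 3 (1.60 log units; beyond the scatter), with 3-fluoro-4-(trifluoromethyl)phenyl entering at 11 heavy atoms against 8 for the group it replaces. The earlier pair left 3-chloro-4-fluorophenyl as the best group shown, but a 5.1-fold lower number from compound 1 to compound 3 (0.71 log units; beyond the scatter) places 3-fluoro-4-(trifluoromethyl)phenyl ahead of it, making compound 3 the strongest of the three inhibitors. Nothing available explains either step.

The compounds shown do not separate the contribution of the trifluoromethyl group from that of the fluorine on the same ring, so 4-(trifluoromethyl)phenyl alone remains an open comparison. From the compounds shown here alone, whether a nitrile or a methoxy group could stand in for the trifluoromethyl group while keeping the number this low is also open.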